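Amide aryl swap in the rat paw edema assay

This account rests on a few compounds, and the source may have more. Where it says the series, first, only, none or still open, it means among the compounds named here.

For the measured compounds named here, compound 2 `COc1ccc(NC(=O)c2c(O)c3cccnc3n(-c3ccccc3)c2=O)cc1` is one of two compounds measured in a functional assay on the whole organism for inhibition, with Rattus norvegicus as the target, read by paw edema, at a dose of 100 mg/kg by the oral route (on this read-out lower numbers stand for less inhibition and higher numbers for more inhibition at the one dose given (going by the name of the read-out)), and compound 2 gives 0.3%. Its companion, compound 1 `O=C(Nc1ccccn1)c1c(O)c2cccnc2n(-c2ccccc2)c1=O`, gives -13.5% in this assay. Going by the values given here, compound 2 thus stands highest of the two numbers, and the only measured step, a number 13.8 percentage points higher from compound 1 to compound 2 (beyond the scatter), concerns a 4-methoxyphenyl in place of pyridin-2-yl on an amide-type nitrogen. The unmeasured compound 3 `O=C(Nc1cccc(Cl)c1)c1c(O)c2cccnc2n(-c2ccccc2)c1=O` differs from compound 2 as follows: 3-chlorophenyl in place of 4-methoxyphenyl on an amide-type nitrogen. Among the compounds with values here, no measured step involves 3-chlorophenyl, so the one known step, which exchanges a different group in the same place, offers only a loose guide: it shows that the single change seen so far at this place was modest in size. On that basis compound 3 is expected to land close to compound 2, with both measured numbers sitting near zero. The step of a number 1.7 percentage points higher from compound 2 to compound 3 (within the scatter) is expected to stay within the scatter, with no clear direction. In this assay compound 3 is estimated at 2%, with a range from -13% to 17%.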

Compound 3, a percentage reported as inhibition, in the whole organism at one dose (the size of the read-out at that dose, not a potency): 7.6%
Beside the measured number, compound 3's estimate is 5.6 percentage points below it; the range from low to high includes it.
By their numbers in this assay, from the lowest: compound 1; then compounds 2 and 3 (each within the scatter of the next).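

In this assay, the exchange of 4-methoxyphenyl for 3-chlorophenyl on the amide-type nitrogen gives a number 7.3 percentage points higher from compound 2 to compound 3 (within the scatter), so two phenyl groups with different substituents in different places cannot be told apart at this position. The pyridin-2-yl amide, by contrast, now differs from a second phenyl amide, with a number 21.1 percentage points higher from compound 1 to compound 3 (beyond the scatter) alongside the earlier a number 13.8 percentage points higher from compound 1 to compound 2 (beyond the scatter). Among these three compounds, the separation therefore lies between compound 1 and the two phenyl amides, while the change of substituent between compound 2 and compound 3 produces no difference that can be read.

The compounds shown leave open whether the unsubstituted phenyl group, or 4-chlorophenyl with the chlorine moved to another place on the ring, would read like compound 2 and compound 3. They also do not settle whether a carboxylic acid or an amine on the phenyl ring, or a longer alkyl chain in place of the ring, would take the read-out beyond the scatter of compound 3. Nothing at hand accounts for the differences seen at this position.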